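The source may hold more compounds than are shown below. What is called first, only, known or untested is meant among the compounds shown, and "the series" means these compounds.

Compound 1 `O=C(/C=C/c1ccc(O)cc1)c1c(O)cccc1OCCC1CCCC1` is a chalcone carrying a cyclopentyl group on its ether chain. In an assay on THP-1 cells for inhibition of nuclear factor NF-kappa-B complex (Homo sapiens), with stated times of 2 h and 16 h (on this read-out higher numbers stand for weaker inhibition and lower numbers for stronger inhibition), compound 1 gives 18000 nM, the highest of the two numbers recorded; compound 2 `CC(C)(C)CCOc1cccc(O)c1C(=O)/C=C/c1ccc(C(=O)O)cc1` gives 2800 nM in this assay, a lower number that lies beyond the usual scatter. Compound 3 `O=C(/C=C/c1ccc(O)cc1)c1c(O)cccc1OCCC1CCCCC1` differs from compound 1 in one place: cyclohexyl in place of cyclopentyl on a saturated chain carbon, two bonds along the chain from an oxygen on an aromatic ring. Going by the values given here, no measured pair shows this change, so only a small step is expected, a 1.2-fold lower number from compound 1 to compound 3 (0.08 log units; within the scatter), within the scatter. Compound 3 is therefore estimated at 15000 nM in this assay, between 6000 nM and 40000 nM.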

Compound 3, half-maximal inhibitory concentration: > 30000 nM
Compound 3: only a limit was reported; the forecaster's own chance of this, stated with the estimate: 15%; middle value at least 2.0-fold (0.30 log units) from the limit.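

Cyclohexyl in place of cyclopentyl on this chain gives an at least 1.6-fold higher number from compound 1 to compound 3 (0.22 log units; that floor lies within the scatter) in this assay, so the larger ring shows no sign of stronger inhibition at this position. The reading for compound 3 is a limit of the assay and not a number, so the full size of the step stays unknown: the limit of > 30000 nM in this assay, at which 1 of the 3 values shown sits.

Going by these compounds, it remains open how an amine or a longer chain at this place would read in this assay. Also open, on these data alone, is whether the same change would read alike on a core carrying the carboxylic acid of compound 2.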